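The compounds below may be only part of what the source reports. "The series", "measured", "known", "first", "only" and "open" are said of these compounds alone.

Series notes. The measured set comprises compound 1 `CC(=O)NCCN(C)c1cccc(OCCCCCCOc2cccc(OC(=O)NC3CCCCC3)c2)c1`, compound 2 `CC(=O)NCCN(C)c1cccc(OCCCCCCOc2cccc(O)c2)c1` and compound 3 `CC(=O)NCCN(C)c1cccc(OCCCCOc2cccc(O)c2)c1`; the unmeasured member is compound 4 `CC(=O)NCCN(C)c1cccc(OCCCCOc2cccc(OC(=O)NC3CCCCC3)c2)c1`. In an assay on cells for displacement of a labelled ligand from melatonin receptor type 1B (Homo sapiens), using the Cheng-Prusoff equation, with a stated time of 90 min (on this read-out lower numbers stand for stronger inhibition and higher numbers for weaker inhibition), compound 1 gives 295 nM, compound 2 gives 331 nM and compound 3 gives 603 nM. Compound 2 and compound 1 differ by cyclohexylcarbamoyl in place of hydrogen on an oxygen on an aromatic ring, and the step is a 1.1-fold lower number from compound 2 to compound 1 (0.05 log units; within the scatter). The difference between the core of compound 3 and that of compound 2 is not broken down here. Compound 3 and compound 4 differ by cyclohexylcarbamoyl in place of hydrogen on an oxygen on an aromatic ring, the same change at the same place. Because the step of a 1.1-fold lower number from compound 2 to compound 1 (0.05 log units; within the scatter) stayed within the scatter, the step from compound 3 to compound 4 in this assay is expected to be similar, a 1.1-fold lower number from compound 3 to compound 4 (0.04 log units; within the scatter). Compound 4 is therefore estimated at 550 nM, between 250 nM and 1200 nM.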

Compound 4, inhibition constant: 53.7 nM
The estimate for compound 4 lay 10-fold (1.01 log units) above the measured number; measured number below the stated range.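

In this assay, cyclohexylcarbamoyl in place of hydrogen on an oxygen on an aromatic ring gives an 11-fold lower number from compound 3 to compound 4 (1.05 log units; beyond the scatter). The size of this step depends on the core carrying it, so a step read on one core in this series does not transfer reliably to the other: the same change on two cores in this assay, a 1.1-fold lower number (0.05 log units; within the scatter) from compound 2 to compound 1 and an 11-fold lower number (1.05 log units; beyond the scatter) from compound 3 to compound 4, 10-fold (1.00 log units) apart, beyond the scatter of two such steps

This rests on a single pair of steps and does not show which difference between the cores is responsible, nor how the step would run on any other core.

Open, from the compounds shown here alone, is how the same change behaves on a core with a longer or a shorter chain. Also open, going by these compounds, is whether a smaller group on the same oxygen, such as acetyl or methylcarbamoyl, shows the same dependence on the core.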